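Trimming a methoxy from the aryl ketone of compound 3

The source may report more compounds than this note shows. Statements on the series, on what has been measured and on what is new or still open speak of the compounds shown alone.

Measured compounds:
compound 1 `COc1cc(-c2cc(/C=C/C(=O)c3ccc(N)cc3)[nH]n2)cc(OC)c1OC`: -93%
compound 2 `COc1cc(-c2cc(/C=C/C(=O)c3ccc(Cl)c(Cl)c3)[nH]n2)cc(OC)c1OC`: -10%
compound 3 `COc1ccc(C(=O)/C=C/c2cc(-c3cc(OC)c(OC)c(OC)c3)n[nH]2)cc1OC`: -97%

In a functional assay on UACC-257 cells (Homo sapiens) for cytotoxicity, read by sulforhodamine B assay, with a stated time of 48 h, tested at 100 uM (a lower number here means a stronger effect, a higher number a weaker effect of the compound at the concentration tested), compound 3 gives -97%, the lowest of the three numbers; its gap to compound 1 lies within the scatter, while its gap to compound 2 is large, as a number 87 percentage points lower from compound 2 to compound 3 (beyond the scatter) shows. Compound 4 `COc1ccc(C(=O)/C=C/c2cc(-c3cc(OC)c(OC)c(OC)c3)n[nH]2)cc1` differs from compound 3 by hydrogen in place of methoxy on an aromatic carbon. Among the compounds with values here, no measured step removes a single methoxy from this aryl ketone, so the nearest guide is a number 4 percentage points lower from compound 1 to compound 3 (within the scatter), a small change when one electron-rich aryl replaces another, against a number 83 percentage points higher from compound 1 to compound 2 (beyond the scatter) for the dichloro aryl. Compound 4 keeps a methoxy-bearing aryl, so a step of about a number 12 percentage points higher from compound 3 to compound 4 (beyond the scatter) is expected, likely within the scatter. Compound 4 is therefore estimated at -85%, between -100% and -30%.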

Compound 4, a percentage reported as activity, at one concentration (the size of the read-out at that concentration, not a potency): -4%
Compound 4: middle estimate off by 81 percentage points, on the low side; the measured number lies above the stated range.
By their numbers in this assay, from the lowest: compounds 3 and 1 (each within the scatter of the next); then compounds 2 and 4 (each within the scatter of the next).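

In this assay, removing a single methoxy, ortho to a methoxy group, is a large step, a number 93 percentage points higher from compound 3 to compound 4 (beyond the scatter), so 3,4-dimethoxyphenyl and 4-methoxyphenyl are far from interchangeable on this ketone. The lone group at the remaining position also matters, as methoxy in place of amino gives a number 89 percentage points higher from compound 1 to compound 4 (beyond the scatter), while the step from the dichloro aryl is only a number 6 percentage points higher from compound 2 to compound 4 (within the scatter). Nothing available explains these steps. From the compounds shown here alone, whether an ethoxy, a hydroxyl or a fluorine at the vacated place would behave like the methoxy stays open.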